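The source may report more compounds than this note shows. Statements on the series, on what has been measured and on what is new or still open speak of the compounds shown alone.

In an ADME assay on HEp-2 cells (Homo sapiens) for cytotoxicity (a higher number here means that more compound is tolerated, a lower number that less compound is tolerated), two compounds sharing one core have been measured. Compound 1 (`CC(=O)NCc1ccc2c(c1)nc(Cn1c(=O)n(C(C)C)c3ccccc31)n2CCC(C)C`) gives 178000 nM, and compound 2 (`CC(C)CCn1c(Cn2c(=O)n(C(C)C)c3ccccc32)nc2cc(CNS(C)(=O)=O)ccc21`) gives 30800 nM, the lower of the two numbers. Among the compounds with values here, the only measured step between them, a 5.8-fold lower number from compound 1 to compound 2 (0.76 log units; beyond the scatter), has methylsulfonyl in place of acetyl on an amine nitrogen. The next case is compound 3 (`C=Cc1ccc2c(c1)nc(Cn1c(=O)n(C(C)C)c3ccccc31)n2CCC(C)C`), which carries a larger change: vinyl in place of (methanesulfonamido)methyl on an aromatic carbon. Compound 3 has lost the whole group that held the earlier change, and vinyl now stands there. The step from compound 1 therefore bears on this one only indirectly. Within the data shown here, it shows that a change within this group can move the number, but no measured compound carries vinyl, and two compounds set no trend. A small shift towards a lower number is expected, probably not clearly beyond the scatter, and even its direction is uncertain. The expected change is a 1.7-fold lower number from compound 2 to compound 3 (0.23 log units; within the scatter). Compound 3 is estimated at 18000 nM, with an expected range from 6000 nM to 60000 nM.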

Compound 3, half-maximal cytotoxic concentration: 6520 nM
Compound 3: the middle estimate sits 2.8-fold (0.44 log units) above what was measured; the range from low to high includes it.
By their numbers in this assay, from the lowest: compound 3; then compound 2; then compound 1.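

In this assay the group on this aromatic carbon can be removed entirely, not just altered, and the number still moves beyond the scatter: the step with vinyl in place of (methanesulfonamido)methyl is a 4.7-fold lower number from compound 2 to compound 3 (0.67 log units; beyond the scatter) and it extends the fall seen within the earlier pair. Measured against the acetamidomethyl compound, the same exchange of group gives a 27-fold lower number from compound 1 to compound 3 (1.44 log units; beyond the scatter) and this is the largest step among the three compounds, so the position can span a wide range of tolerated concentrations while the rest of the structure stays fixed. Both groups that carry an amine nitrogen now stand above vinyl, which has no hydrogen-bond donors or acceptors and only two heavy atoms, although three compounds cannot separate these features from one another.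

The compounds shown leave open whether the low number follows from the vinyl group itself or from the loss of the longer substituent, a question that an ethyl group, a plain hydrogen, an aminomethyl group or a carboxylic acid on this carbon would bear on. Nothing shown here offers an explanation for any of these steps.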